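The source may hold more compounds than are shown below. What is called first, only, known or untested is meant among the compounds shown, and "the series" means these compounds.

In a functional assay on HeLa cells (Homo sapiens) for antiproliferative activity, read by MTT assay, with a stated time of 72 h (a lower number here means a stronger inhibitor, a higher number a weaker inhibitor), compound 1 `O=C1COc2ccc(-c3cccc(NS(=O)(=O)c4ccc(F)cc4)c3)cc2N1c1ccc(Cl)cc1` gives 35000 nM. Compound 2 `O=C1COc2ccc(-c3cccc(NS(=O)(=O)c4ccc(F)cc4)c3)cc2N1c1ccccc1` differs from it by hydrogen in place of chloro on an aromatic carbon, and in this assay compound 2 gives 17700 nM, so that a 2.0-fold lower number from compound 1 to compound 2 (0.30 log units; within the scatter). Compound 3 `O=C1COc2ccc(-c3cnc(Cl)c(NS(=O)(=O)c4ccc(F)cc4)c3)cc2N1c1ccc(Cl)cc1` carries a different core, and the difference between the two cores is not broken down here. For compound 3 this assay reports only a limit, > 40000 nM, which is the limit of > 40000 nM in this assay, at which 1 of the 3 values shown sits. Compound 4 `O=C1COc2ccc(-c3cnc(Cl)c(NS(=O)(=O)c4ccc(F)cc4)c3)cc2N1c1ccccc1` stands to compound 3 as compound 2 stands to compound 1, by hydrogen in place of chloro on an aromatic carbon, the same change at the same place. Since a 2.0-fold lower number from compound 1 to compound 2 (0.30 log units; within the scatter) lay within the scatter, a step of similar small size is expected here, though starting from a limit. Compound 4 is expected to give 35000 nM in this assay, within 15000 nM to 80000 nM. That expectation amounts to an estimated step of an at least 1.1-fold lower number from compound 3 to compound 4 (0.05 log units; that floor lies within the scatter).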

Compound 4, half-maximal inhibitory concentration: 10300 nM
Beside the measured number, compound 4's estimate is 3.4-fold (0.53 log units) above it, and the stated range ends above it.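

In this assay, the change from 4-chlorophenyl to phenyl gives an at least 3.8-fold lower number from compound 3 to compound 4 (0.58 log units; beyond the scatter), while on the other core the same change gives a 2.0-fold lower number from compound 1 to compound 2 (0.30 log units; within the scatter). For compound 3 the assay reports only a limit, > 40000 nM, so the step to compound 4 is a floor and not an exact size. The change is therefore not shown to act more strongly on one core than on the other, nor to act equally on both: the same change on two cores in this assay, a 2.0-fold lower number (0.30 log units; within the scatter) from compound 1 to compound 2 and an at least 3.8-fold lower number (0.58 log units; beyond the scatter) from compound 3 to compound 4; the limit leaves it open whether they differ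

The compounds shown leave open what fluoro, methoxy or an amine would give in place of that chloro. They also leave open how either core would respond with a methyl group in place of the 4-fluorophenyl on the sulfonamide.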